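Cytotoxicity notes: cyclohexenyl replaced by tert-butylphenyl

The compounds below may be only part of what the source reports. "The series", "measured", "known", "first", "only" and "open" are said of these compounds alone.

Measured so far in an ADME assay on HEK293 cells (Homo sapiens) for cytotoxicity, read by MTT assay, with a stated time of 24 h; on this read-out higher numbers stand for weaker inhibition and lower numbers for stronger inhibition:
compound 1 `O=C1O/C(=C\Cn2cc(C3=CCCCC3)nn2)C(OCc2ccccc2)=C1OCc1ccccc1` gives > 100000 nM, a limit of the assay and not a number.
compound 2 `O=C1NC(O)(CCn2cc(C3=CCCCC3)nn2)C(OCc2ccccc2)=C1OCc1ccccc1` gives 70000 nM.
compound 3 `O=C1NC(O)(CCn2cc(Cc3ccccc3)nn2)C(OCc2ccccc2)=C1OCc1ccccc1` gives 86000 nM.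

Compound 1 stands at the limit of > 100000 nM in this assay, at which 1 of the 3 values shown sits, and has no number of its own. Compound 4 `CC(C)(C)c1ccc(-c2cn(C/C=C3\OC(=O)C(OCc4ccccc4)=C3OCc3ccccc3)nn2)cc1` differs from compound 1 by 4-(tert-butyl)phenyl in place of cyclohex-1-en-1-yl on an aromatic carbon. Among the measured compounds shown here, the one step measured at the same position, a 1.2-fold higher number from compound 2 to compound 3 (0.09 log units; within the scatter), stayed within the scatter, and nothing measured speaks for a move beyond it here. Compound 4 is therefore expected near the same limit: a number no higher from compound 1 to compound 4 (the limit leaves the size open) is the expected step. Compound 4 is estimated at 100000 nM, with a range from 40000 nM to 300000 nM, and a limit rather than a number is likely to be reported.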

Compound 4, half-maximal inhibitory concentration: > 100000 nM
Compound 4: no number, only a limit (the forecaster's own chance of this, stated with the estimate: 60%); the middle value sits exactly at the limit.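

In this assay, compound 1 and compound 4 both give limits and not numbers, so no step between them can be read: the limit of > 100000 nM in this assay, at which 2 of the 4 values shown sit.
The compounds shown leave open how far 4-(tert-butyl)phenyl in place of cyclohex-1-en-1-yl shifts the read-out on the core of compound 1.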